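Methoxy for trifluoromethyl on a weakly antiproliferative series

The source may hold more compounds than are shown below. What is called first, only, known or untested is meant among the compounds shown, and "the series" means these compounds.

Of the compounds shown here, three sharing one core have been measured in a functional assay on A549 cells (Homo sapiens) for antiproliferative activity, read by MTT assay, with a stated time of 72 h; a higher number here means a weaker inhibitor, a lower number a stronger inhibitor. Compound 1 `Fc1ccc(-c2csc(N3N=C(c4ccc(N5CCCCC5)cc4)CC3c3ccc(Cl)cc3)n2)cc1` gives 70200 nM in this assay. Compound 2 `Clc1ccc(-c2csc(N3N=C(c4ccc(N5CCCCC5)cc4)CC3c3ccc(Cl)cc3)n2)cc1` gives 46400 nM in this assay. Compound 3 `FC(F)(F)c1ccc(-c2csc(N3N=C(c4ccc(N5CCCCC5)cc4)CC3c3ccc(Cl)cc3)n2)cc1` gives 42000 nM in this assay, the smallest of the three numbers, though its distance to the other two stays within the scatter. The steps among them are small: a 1.5-fold lower number from compound 1 to compound 2 (0.18 log units; within the scatter), a 1.7-fold lower number from compound 1 to compound 3 (0.22 log units; within the scatter) and a 1.1-fold lower number from compound 2 to compound 3 (0.04 log units; within the scatter) all lie within the scatter, so exchanging the substituent on this aromatic carbon has not yet moved the number in a measurable way.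

Compound 4 `COc1ccc(-c2csc(N3N=C(c4ccc(N5CCCCC5)cc4)CC3c3ccc(Cl)cc3)n2)cc1` is the next member, carrying the change (methoxy in place of trifluoromethyl on an aromatic carbon). Within the data shown here, no measured step involves a methoxy group, so the expectation rests only on the three exchanges above, none of which moved the number beyond the scatter. The step of a 1.2-fold higher number from compound 3 to compound 4 (0.08 log units; within the scatter) is therefore expected to stay within the scatter. Compound 4 is estimated to give 50000 nM in this assay, within a range from 20000 nM to 120000 nM.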

Compound 4, half-maximal inhibitory concentration: > 100000 nM
Compound 4 ended at the assay's limit; the forecaster's own chance of this, stated with the estimate: 15%; middle value at least 2.0-fold (0.30 log units) away from the limit.
By their numbers in this assay, from the lowest: compounds 3, 2 and 1 (each within the scatter of the next). At a limit, above all of these: compound 4.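

Compound 4 can be read only as a limit of this assay, not as a number: the limit of > 100000 nM in this assay, at which 1 of the 4 values shown sits.

Fluoro, chloro and trifluoromethyl had left the number unmoved beyond the scatter, but this position does respond to the exchange for methoxy, with an at least 2.3-fold higher number from compound 3 to compound 4 (0.37 log units; beyond the scatter) and an at least 2.1-fold higher number from compound 2 to compound 4 (0.33 log units; beyond the scatter), the first steps in the series to pass the scatter. Against fluoro the separation remains unproven, with an at least 1.4-fold higher number from compound 1 to compound 4 (0.15 log units; that floor lies within the scatter).

Going by these compounds, the true size of all three steps stays open, since the value of compound 4 lies somewhere past the limit. Also open, on these data alone, is whether the shift belongs to methoxy alone or would also appear with a hydroxyl, an amine or a longer ether chain such as ethoxy on this aromatic carbon.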